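Branched chain versus ring on the amine of compound 2

The source may hold more compounds than are shown below. What is called first, only, known or untested is meant among the compounds shown, and "the series" means these compounds.

Compound 1 `CCC(CC)Nc1ncnc2c1ncn2C1O[C@H](CO)[C@@H](O)[C@H]1O` gives 0.75 nM in an assay on cell membranes for binding affinity to adenosine receptor A1 (Cavia porcellus), read by radioligand binding; a lower number here means a stronger inhibitor, a higher number a weaker inhibitor. Compound 2 `CC1(Nc2ncnc3c2ncn3C2O[C@H](CO)[C@@H](O)[C@H]2O)CCCCC1` gives 70 nM in this assay.

Compound 2 therefore stands at the highest number of the two, its nearest neighbour being compound 1, with the step of a 93-fold higher number from compound 1 to compound 2 (1.97 log units; beyond the scatter). Compound 3 `CCCC(CCC)Nc1ncnc2c1ncn2C1O[C@H](CO)[C@@H](O)[C@H]1O` differs from compound 2 by 1-propylbutyl in place of 1-methylcyclohexyl on a nitrogen on an aromatic ring. That one step is the only one that bears on the change, and it was large; since compound 3 returns to an open branched chain as in compound 1, a drop in number is expected, estimated as a 35-fold lower number from compound 2 to compound 3 (1.54 log units; beyond the scatter). Compound 3 is accordingly expected near 2 nM, within 0.5 nM to 8 nM.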

Compound 3, inhibition constant: 3.3 nM
Beside the measured number, compound 3's estimate is 1.7-fold (0.22 log units) below it; the range from low to high includes it.
By their numbers in this assay, from the lowest: compound 1; then compound 3; then compound 2.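

With the count of carbon atoms unchanged, opening the ring into 1-propylbutyl gives a 21-fold lower number from compound 2 to compound 3 (1.33 log units; beyond the scatter) in this assay, so the weak binding of compound 2 does not follow from that count alone. The longer open chain is not free of cost, with a 4.4-fold higher number from compound 1 to compound 3 (0.64 log units; beyond the scatter), but this step is far smaller. Nothing available explains either step.

As far as these compounds go, whether cyclohexyl without the methyl, or cyclopentyl, behaves like 1-methylcyclohexyl remains open. So does the effect of a hydroxyl group on the open chain.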